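Trifluoromethyl Removal and Tolerance in Bovine Kidney Cells

A few compounds are considered here, and "the series" means these few. Any claim that something is new, unique, unknown or untested is made for them only; others in the source may bear on it.

Compound 2 `Fc1ccc(F)c(/N=N/Nc2cccc(C(F)(F)F)c2)c1` and compound 1 `Fc1ccc(F)c(/N=N/Nc2ccccc2)c1` share a core and differ by hydrogen in place of trifluoromethyl on an aromatic carbon. In an ADME assay on MDBK cells (Bos taurus) for cytotoxicity, read by MTT assay, with a stated time of 96 h (a lower number here means that less compound is tolerated, a higher number that more compound is tolerated), compound 2 reaches only the assay limit of > 100000 nM. Compound 1 likewise gives only the limit of > 100000 nM. The step that the two limits leave unreadable from compound 2 to compound 1 therefore cannot be sized. Compound 3 `Cc1c(/N=N/c2cccc(C(F)(F)F)c2)ccc(NC[C@@H]2CCCN3CCCC[C@H]23)c1C` has a different core; how its core differs from that of compound 2 is not broken down here. In this assay compound 3 gives 52000 nM. Compound 1 and compound 2 together account for (the limit of > 100000 nM in this assay, at which 2 of the 3 values shown sit). Compound 4 `Cc1c(/N=N/c2ccccc2)ccc(NC[C@@H]2CCCN3CCCC[C@H]23)c1C` differs from compound 3 by hydrogen in place of trifluoromethyl on an aromatic carbon, the same change as that from compound 2 to compound 1. The measured pair gives no readable size for this change. The corresponding step is therefore estimated as small, at a 1.3-fold higher number from compound 3 to compound 4 (0.10 log units; within the scatter). Compound 4 is expected to give about 65000 nM in this assay, between 30000 nM and 140000 nM.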

Compound 4, half-maximal cytotoxic concentration: 48000 nM
Compound 4: middle estimate off by 1.4-fold (0.13 log units), on the high side, and the stated range covers the measured number.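

In this assay, hydrogen in place of trifluoromethyl gives a 1.1-fold lower number from compound 3 to compound 4 (0.03 log units; within the scatter), so on this core the change leaves tolerance within the usual scatter. The same change on the core of compound 2 cannot be read, because both compounds of that pair sit at a limit of the assay: the limit of > 100000 nM in this assay, at which 2 of the 4 values shown sit. The series therefore offers one readable step on one core, and it does not show whether the change carries the same size from one core to the other.

The compounds shown leave open what a nitrile, an amine or a carboxylic acid in place of trifluoromethyl would do on the core of compound 4. They also leave open whether any such group would move tolerance beyond the scatter.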